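Extending the sulfonyl chain on a piperidine nitrogen

A few compounds are considered here, and "the series" means these few. Any claim that something is new, unique, unknown or untested is made for them only; others in the source may bear on it.

Of the compounds shown here, two sharing one core have been measured. Compound 1 `CCOC(=O)N1CCC(Oc2ncnc3c2CCN3c2ccc(S(C)(=O)=O)cc2F)CC1` gives 135% in a functional assay on CHO-K1 cells with Glucose-dependent insulinotropic receptor (Homo sapiens) as the target, read by a luciferase reporter, with a stated time of 5 h (a higher number here means a larger maximal response, a lower number a smaller maximal response), while compound 2 `CCS(=O)(=O)N1CCC(Oc2ncnc3c2CCN3c2ccc(S(C)(=O)=O)cc2F)CC1` gives 51%, the lower of the two numbers; the change of a number 84 percentage points lower from compound 1 to compound 2 (beyond the scatter) came with ethylsulfonyl in place of ethoxycarbonyl on an amine nitrogen in a ring. Compound 3 `CC(C)S(=O)(=O)N1CCC(Oc2ncnc3c2CCN3c2ccc(S(C)(=O)=O)cc2F)CC1` differs from compound 2 by methyl in place of hydrogen on a saturated chain carbon bound to a saturated chain carbon and a sulfonyl sulfur. Among the compounds with values here, the only measured step swaps one whole group for another of a different kind, so it does not speak directly to growing the chain beside the sulfonyl sulfur by one carbon. Within the data shown here, with no comparable step to lean on, the expectation for compound 3 is a change of about a number 4 percentage points higher from compound 2 to compound 3 (within the scatter) in this assay, which lies within the usual scatter. Compound 3 is therefore estimated at 55%, with a range from 30% to 85%.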

Compound 3, largest response reached (reported as percent of maximum), in percent of the reference or control that the assay uses: 62%
Beside the measured number, compound 3's estimate is 7 percentage points below it; the range from low to high includes it.
By their numbers in this assay, from the lowest: compound 2; then compound 3; then compound 1.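

Within the sulfonyl series, the chain on the sulfonyl sulfur is not a silent position: methyl in place of hydrogen on the saturated chain carbon bound to that sulfur gives a number 11 percentage points higher from compound 2 to compound 3 (beyond the scatter) in this assay and so shows that one added carbon can shift the maximal response. That gain is small against the gap that remains to the carbamate, since isopropylsulfonyl in place of ethoxycarbonyl on the ring nitrogen still gives a number 73 percentage points lower from compound 1 to compound 3 (beyond the scatter) in this assay and leaves compound 1 the highest of the three. No data here explain why either change alters the response.

Still open, going by these compounds, is whether a longer chain, a tert-butyl group or a cyclopropyl ring on the sulfonyl sulfur would raise the response further. An isopropoxycarbonyl group on the ring nitrogen would test whether the same branching also counts in the carbamate.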